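Compound 3: A Hydroxylated Ring on the Side Chain

The source may hold more compounds than are shown below. What is called first, only, known or untested is meant among the compounds shown, and "the series" means these compounds.

Measured so far in an in vivo ADME assay on the whole organism for pharmacokinetics, with Canis familiaris (Canis lupus familiaris) as the target; a higher number here means that a larger share of the oral dose reaches the circulation, a lower number that a smaller share of the oral dose reaches the circulation:
- Compound 1 `Nc1noc2ccc(-n3nc(C(F)(F)F)c4c3C(=O)N(c3ccc(-c5ccccc5CN5CCCC5)cc3F)CC4)cc12`: 85%
- Compound 2 `CN(C)Cc1ccccc1-c1ccc(N2CCc3c(C(F)(F)F)nn(-c4ccc5onc(N)c5c4)c3C2=O)c(F)c1`: 83%

Compound 2, at 83%, stands level with compound 1 within the usual scatter. Compound 3 `Nc1noc2ccc(-n3nc(C(F)(F)F)c4c3C(=O)N(c3ccc(-c5ccccc5CN5CC[C@@H](O)C5)cc3F)CC4)cc12` brings one change: 3-hydroxypyrrolidin-1-yl in place of dimethylamino on a saturated chain carbon bound to an aromatic carbon. For the measured compounds named here, the only measured step at this place is a number 2 percentage points lower from compound 1 to compound 2 (within the scatter), which was within the scatter. Going by the values given here, that step swapped pyrrolidin-1-yl for dimethylamino, but no measured compound shows what the 3-hydroxypyrrolidin-1-yl group does, so it offers only loose guidance. A modest drop is expected, with wide uncertainty: the expected step is a number 7 percentage points lower from compound 2 to compound 3 (within the scatter). For compound 3 the estimate is 76%, with an expected range of 55% to 92%.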

Compound 3, oral bioavailability: 81%
For compound 3 the middle estimate is 5 percentage points below the measured one, within the range that was stated.
By their numbers in this assay, from the lowest: compounds 3, 2 and 1 (each within the scatter of the next).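

In this assay, the larger hydroxylated ring gives a number 2 percentage points lower from compound 2 to compound 3 (within the scatter) and so stands level with the small dimethylamino group. Adding only the hydroxy group to the ring gives a number 4 percentage points lower from compound 1 to compound 3 (within the scatter) and also leaves the number level. This position on the saturated chain carbon therefore accepts a hydroxylated ring with a hydrogen-bond donor, with no step beyond the scatter. On these data alone, whether a morpholine ring or a carboxylic acid at this place would keep the number as high remains open. Nothing available explains why the hydroxy group leaves this number level.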